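Side-chain variation on the saturated ring carbon

This account rests on a few compounds, and the source may have more. Where it says the series, first, only, none or still open, it means among the compounds named here.

Measured compounds:
compound 1 `CCC(C)n1ncn(-c2ccc(N3CCN(c4ccc(OC[C@@H]5COC(c6ccc(Cl)cc6Cl)O5)cc4)CC3)cc2)c1=O` gives 328 nM
compound 2 `CCC(C)n1ncn(-c2ccc(N3CCN(c4ccc(OC[C@@H]5CO[C@@](CN(C)C)(c6ccc(Cl)cc6Cl)O5)cc4)CC3)cc2)c1=O` gives 1400 nM
compound 3 `CCC(C)n1ncn(-c2ccc(N3CCN(c4ccc(OC[C@@H]5CO[C@@](CN6CCNCC6)(c6ccc(Cl)cc6Cl)O5)cc4)CC3)cc2)c1=O` gives 608 nM

These numbers come from a functional assay on HUVEC cells (Homo sapiens), read by scintillation counting and thymidine incorporation, with a stated time of 24 h; on this read-out higher numbers stand for weaker inhibition and lower numbers for stronger inhibition. Compound 2 stands highest of the three; its nearest neighbour is compound 3, with a 2.3-fold lower number from compound 2 to compound 3 (0.36 log units; beyond the scatter), and compound 1, which carries no substituent at that carbon, lies furthest below it.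

Compound 4 `CCC(C)n1ncn(-c2ccc(N3CCN(c4ccc(OC[C@@H]5CO[C@@](Cn6ccnc6C)(c6ccc(Cl)cc6Cl)O5)cc4)CC3)cc2)c1=O` differs from compound 2 as follows: 2-methyl-1H-imidazol-1-yl in place of dimethylamino on a saturated chain carbon bound to a saturated ring carbon. Within the data shown here, the only measured step at the same place is a 2.3-fold lower number from compound 2 to compound 3 (0.36 log units; beyond the scatter), where a larger group in place of dimethylamino gave a modest lowering. On that single precedent a step of similar size downward is expected in this assay, though nothing measured tells how an aromatic five-membered ring behaves at this position.

Compound 4 is therefore expected to give about 700 nM, within 250 nM to 2000 nM, which means an estimated 2.0-fold lower number from compound 2 to compound 4 (0.30 log units; within the scatter).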

Compound 4, half-maximal inhibitory concentration: 173 nM
Estimate against measurement, compound 4: 4.0-fold (0.61 log units) above; measured number outside the range, below it.
By their numbers in this assay, from the lowest: compounds 4, 1 and 3 (each within the scatter of the next, the first and the last beyond it); then compound 2.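

In this assay 2-methyl-1H-imidazol-1-yl in place of dimethylamino gives an 8.1-fold lower number from compound 2 to compound 4 (0.91 log units; beyond the scatter) and in place of piperazin-1-yl gives a 3.5-fold lower number from compound 3 to compound 4 (0.55 log units; beyond the scatter) at the same place. A five-membered aromatic ring on this chain carbon is therefore accepted, and compound 4 stands within the scatter of compound 1, which has no substituent at that carbon. Nothing measured here explains the difference.

Open, going by these compounds, is whether the ring alone or its methyl carries the step. The unmethylated 1H-imidazol-1-yl group would separate the two, and a 1,2,4-triazol-1-yl group would test the ring nitrogens.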